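Swapping furan for chlorophenyl: cytotoxicity on MT4 cells

This account rests on a few compounds, and the source may have more. Where it says the series, first, only, none or still open, it means among the compounds named here.

Compound 3 `Cc1cc(C#N)cc(C)c1Oc1nc(Nc2ccc(C#N)cc2)ncc1-c1ccco1` stands at a limit in an ADME assay on MT4 cells (Homo sapiens) for cytotoxicity, read by MTT assay, with a stated time of 5 days; a higher number here means that more compound is tolerated, a lower number that less compound is tolerated: compound 3 gives > 306000 nM, which is a limit of the measurement rather than a number (the limit of > 306000 nM in this assay, at which 1 of the 3 values shown sits). Compound 1 `COc1ccc(-c2cnc(Nc3ccc(C#N)cc3)nc2Oc2c(C)cc(C#N)cc2C)cc1` likewise reaches a limit, giving > 279000 nM (the limit of > 279000 nM in this assay, at which 1 of the 3 values shown sits). Compound 2 `Cc1ccc(-c2cnc(Nc3ccc(C#N)cc3)nc2Oc2c(C)cc(C#N)cc2C)cc1` gives 26100 nM. The change to compound 4 `Cc1cc(C#N)cc(C)c1Oc1nc(Nc2ccc(C#N)cc2)ncc1-c1ccc(Cl)cc1` is 4-chlorophenyl in place of furan-2-yl on an aromatic carbon. Among the measured compounds shown here, two measured steps bear on it: an at least 11-fold higher number from compound 2 to compound 3 (1.06 log units; beyond the scatter), and an at least 10-fold lower number from compound 1 to compound 2 (1.02 log units; beyond the scatter), while a step that the two limits leave unreadable from compound 1 to compound 3. Compound 4, like compound 2 and unlike compound 3, carries a six-membered aromatic ring of carbon only at that place, and compound 2 gives 26100 nM. A lower number is therefore expected for compound 4, an at least 7.6-fold lower number from compound 3 to compound 4 (0.88 log units; beyond the scatter). The estimate for compound 4 is 40000 nM, ranging from 10000 nM to 300000 nM.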

Compound 4, half-maximal cytotoxic concentration: 72600 nM
Compound 4: middle estimate off by 1.8-fold (0.26 log units), on the low side, and the stated range covers the measured number.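

In this assay, compound 4 gives an at least 4.2-fold lower number from compound 3 to compound 4 (0.62 log units; beyond the scatter), so a 4-chlorophenyl group at this place, like the 4-methylphenyl group of compound 2, stands lower than furan-2-yl. Compound 1 goes against any rule about a six-membered ring of carbon only here: the group on that ring matters, with a 2.8-fold higher number from compound 2 to compound 4 (0.44 log units; beyond the scatter) and an at least 3.8-fold lower number from compound 1 to compound 4 (0.58 log units; beyond the scatter). Chloro thus gives a number that methyl and methoxy do not.

Compound 1 and compound 3 each stand at a limit, so the step between them cannot be read. Open too, going by these compounds, is how an amine or a carboxylic acid on that ring would read.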